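The source may hold more compounds than are shown below. What is called first, only, known or untested is meant among the compounds shown, and "the series" means these compounds.

Measured so far in a physicochemical assay for lipophilicity, at pH 7.4; on this read-out lower numbers stand for lower lipophilicity and higher numbers for higher lipophilicity:
- compound 1 `Cc1cc(NC(=O)C2CCCCC2)nn1Cc1cc(Cl)ccc1OCC(C)C`: > 3.7 (a limit)
- compound 2 `Cc1cc(NC(=O)OC(C)(C)C)nn1Cc1cc(Cl)ccc1OCC(C)C`: > 3.7 (a limit)

Compound 2 stands at > 3.7 as a limit and not a number. The series as a whole stands at the limit of > 3.7 in this assay, at which 2 of the 2 values shown sit, and has no measured number yet.

The next compound is compound 3 `Cc1cc(NC(=O)OC(C)(C)C(F)(F)F)nn1Cc1cc(Cl)ccc1OCC(C)C` with the change trifluoromethyl in place of methyl on a saturated chain carbon bound to an oxygen next to a carbonyl group and two saturated chain carbons in which trifluoromethyl takes the place of methyl, so that tert-butoxy becomes 1-methyl-1-(trifluoromethyl)ethoxy.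

Among the measured compounds shown here, the only measured step is a step that the two limits leave unreadable from compound 1 to compound 2 and it offers no size to carry over. The expectation therefore rests on the structural change alone. An upward move of moderate size is expected, namely a step that the limit leaves unreadable from compound 2 to compound 3 in this assay as a rough estimate. Compound 3 is estimated at 4.2 with an expected range of 3.7 to 4.8. A limit rather than a number is the likely outcome for compound 3.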

Compound 3, distribution coefficient: 3.5
For compound 3 the middle estimate is 0.70 log units above the measured one; measured number outside the range, below it.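

In this assay, among the compounds shown here, compound 3 gives 3.5, the only number so far rather than a limit. On a saturated chain carbon bound to an oxygen next to a carbonyl group, trifluoromethyl in place of methyl gives a number at least 0.20 log units lower from compound 2 to compound 3 (that floor lies within the scatter), while 1-methyl-1-(trifluoromethyl)ethoxy in place of cyclohexyl on a carbonyl carbon gives a number at least 0.20 log units lower from compound 1 to compound 3 (that floor lies within the scatter). Both steps are readable only as floors because compound 1 and compound 2 each carry a limit and not a number: the limit of > 3.7 in this assay, at which 2 of the 3 values shown sit.

From the compounds shown here alone, the true size of either step remains open, so it is unclear how far the change reaches beyond the scatter. Also open, going by these compounds, is whether a single fluorine, a nitrile or an amine on the same carbon would move this read-out in the same direction.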